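Moving the Chlorine: From Compound 3 to Compound 4

This account rests on a few compounds, and the source may have more. Where it says the series, first, only, none or still open, it means among the compounds named here.

Compound 1 `O=C(O)CCCCC(CCSC(=O)c1ccccc1)SC(=O)c1ccccc1`: "not active" (no number reported)
Compound 2 `O=C(CCCCC(CCSC(=O)c1ccccc1)SC(=O)c1ccccc1)Nc1ccccc1`: 3.12%
Compound 3 `O=C(CCCCC(CCSC(=O)c1ccccc1)SC(=O)c1ccccc1)Nc1ccccc1Cl`: "not active" (no number reported)

All three compounds were tested in a functional assay on HO8910 cells (Homo sapiens) for inhibition, read by MTT assay, with a stated time of 24 h, tested at 0.1 ug/mL; on this read-out lower numbers stand for less inhibition of growth and higher numbers for more inhibition of growth at the one concentration tested. Compound 3 has no single number, and its entry reads "not active" (no number reported). Among the measured compounds shown here, compound 1 is the one other compound without a number. For the measured compounds named here, the only number in the set belongs to compound 2, at 3.12%.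

Compound 4 `O=C(CCCCC(CCSC(=O)c1ccccc1)SC(=O)c1ccccc1)Nc1cccc(Cl)c1` has not yet been measured. Its structure differs from that of compound 3 as follows: 3-chlorophenyl in place of 2-chlorophenyl on an amide-type nitrogen. In words, 3-chlorophenyl stands in place of 2-chlorophenyl on an amide-type nitrogen, with the same atoms joined differently.

Going by the values given here, no measured pair shows what this change does. The expectation therefore rests on the low readings of the set, with compound 2 at 3.12% and compound 3 at "not active" (no number reported). No step beyond the scatter is expected in this assay, and another entry without a number is quite possible. Compound 4 is estimated at 4%, with an expected range from 0% to 13%.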

Compound 4, percent growth inhibition at one concentration: 9.02%
Estimate against measurement, compound 4: 5 percentage points below; low and high end bracket the measured number.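

In this assay compound 4 gives 9.02% as a readable number, while compound 3, with 2-chlorophenyl on the amide-type nitrogen, stands as "not active" (no number reported) and so this pair cannot be read as a step. Chloro in place of hydrogen on an aromatic carbon gives a number 5.9 percentage points higher from compound 2 to compound 4 (within the scatter) in this assay and so shows no change that can be told apart from the usual scatter of this read-out. Nothing among the data shown accounts for the entries of these compounds. On these data alone, whether an amine or a longer chain in place of the chlorophenyl group on this nitrogen would alter the reading stays open. The compounds shown also leave open how any of them would read at another concentration or after another exposure time.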